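Long groups against a small one at one aromatic carbon

The compounds below may be only part of what the source reports. "The series", "measured", "known", "first", "only" and "open" are said of these compounds alone.

Compound 1 `COc1ccc(N(C)c2nc(C)nc3ccccc23)cc1OCCCCCC[Se]C#N`: 3550 nM
Compound 2 `COc1ccc(N(C)c2nc(C)nc3ccccc23)cc1C(=O)OCCC[Se]C#N`: 1180 nM
Compound 3 `COc1ccc(N(C)c2nc(C)nc3ccccc23)cc1[Se]C`: 10 nM

All three values come from a functional assay on MDA-MB-231 cells (Homo sapiens) for inhibition, read by MTT assay, with a stated time of 48 h; a lower number here means a stronger inhibitor, a higher number a weaker inhibitor. Compound 3 has the lowest number of the three, and its steps to both other compounds lie beyond the scatter. Compound 4 `COc1ccc(N(C)c2nc(C)nc3ccccc23)cc1C(=O)OCCCC[Se]C#N` has not yet been measured. The change that leads to it from compound 3 is a group of 10 heavy atoms (6 carbon, 1 nitrogen, 2 oxygen, 1 selenium; no ring) in place of a group of 2 heavy atoms (1 carbon, 1 selenium; no ring), on an aromatic carbon. The site is an aromatic carbon of a six-membered aromatic ring of carbon only, ortho to a methoxy group.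

Within the data shown here, two measured steps bear on this change, read in reverse: a 360-fold lower number from compound 1 to compound 3 (2.55 log units; beyond the scatter) and a 120-fold lower number from compound 2 to compound 3 (2.07 log units; beyond the scatter). Both are large, and each goes from a long group to the same small group. The two long groups themselves differ only modestly, with a 3.0-fold lower number from compound 1 to compound 2 (0.48 log units; beyond the scatter). Among the measured compounds shown here, the group entering compound 4 is closest in composition to the one in compound 2, so compound 2 at 1180 nM is the nearer guide. A large step towards a higher number is therefore expected, namely a 150-fold higher number from compound 3 to compound 4 (2.18 log units; beyond the scatter). For compound 4 the estimated value is 1500 nM, with an expected range from 500 nM to 4500 nM.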

Compound 4, half-maximal inhibitory concentration: 554 nM
The estimate for compound 4 lay 2.7-fold (0.43 log units) above the measured number, within the range that was stated.
By their numbers in this assay, from the lowest: compound 3; then compound 4; then compound 2; then compound 1.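

In this assay, the step of a 55-fold higher number from compound 3 to compound 4 (1.74 log units; beyond the scatter) adds a third long group at this aromatic carbon, ortho to a methoxy group, and the large gap from the small group holds for all three long groups, though this one falls short of the other two gaps. The new pair also gives the first change made within the long group itself, on a saturated chain carbon, and a 2.1-fold lower number from compound 2 to compound 4 (0.33 log units; beyond the scatter) shows that the longer chain on the ester moves the number, if only modestly and not far beyond the scatter. Set against the chain joined through oxygen alone, the step of a 6.4-fold lower number from compound 1 to compound 4 (0.81 log units; beyond the scatter) is also modest, so the differences among the long groups remain much smaller than the gap between any of them and the small group in compound 3.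

No measurement to hand accounts for any of these steps. The compounds shown leave open whether a still longer chain on the ester would lower the number further, and whether an amide in place of the ester, or a methylthio group in place of the small selenium group, would keep the number of compound 3 or of the long-chain compounds.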